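A few compounds are considered here, and "the series" means these few. Any claim that something is new, unique, unknown or untested is made for them only; others in the source may bear on it.

In a functional assay on CCRF-CEM cells (Homo sapiens), read by MTT assay, with a stated time of 72 h (a lower number here means a stronger inhibitor, a higher number a weaker inhibitor), compound 1 `COc1ncnc2c1c(-c1ccoc1)cn2[C@@H]1O[C@H](CO)[C@@H](O)[C@H]1O` gives 110 nM. Among the compounds with values here, compound 2 `CN(C)c1ncnc2c1c(-c1ccoc1)cn2[C@@H]1O[C@H](CO)[C@@H](O)[C@H]1O` gives 13300 nM; the step of a 120-fold higher number from compound 1 to compound 2 (2.08 log units; beyond the scatter) is the only measured step in the set. Compound 3 `CSc1ncnc2c1c(-c1ccccc1)cn2[C@@H]1O[C@H](CO)[C@@H](O)[C@H]1O` gives > 20000 nM, which is a limit of the assay and not a number. Compound 3 thus sits at the limit of > 20000 nM in this assay, at which 1 of the 3 values shown sits. Compound 4 `CSc1ncnc2c1c(-c1ccoc1)cn2[C@@H]1O[C@H](CO)[C@@H](O)[C@H]1O` differs from compound 3 by furan-3-yl in place of phenyl on an aromatic carbon. Within the data shown here, no measured step concerns this change, and the one measured step touches a different group, so it offers no direct guide. The only point of reference is that compound 1, which also carries furan-3-yl, gives 110 nM. A lower number is therefore expected, with a step of size an at least 13-fold lower number from compound 3 to compound 4 (1.12 log units; beyond the scatter). Compound 4 is expected to give 1500 nM, between 200 nM and 15000 nM.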

Compound 4, half-maximal inhibitory concentration: 14200 nM
The estimate for compound 4 lay 9.5-fold (0.98 log units) below the measured number; low and high end bracket the measured number.
By their numbers in this assay, from the lowest: compound 1; then compounds 2 and 4 (each within the scatter of the next). At a limit, above all of these: compound 3.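

The step for furan-3-yl in place of phenyl on an aromatic carbon is only a floor, an at least 1.4-fold lower number from compound 3 to compound 4 (0.14 log units; that floor lies within the scatter), because its reference value is a limit of the assay and not a number: the limit of > 20000 nM in this assay, at which 1 of the 4 values shown sits.

With furan-3-yl held, methylsulfanyl in place of methoxy costs heavily, a 130-fold higher number from compound 1 to compound 4 (2.11 log units; beyond the scatter), while methylsulfanyl in place of dimethylamino gives no separation, a 1.1-fold higher number from compound 2 to compound 4 (0.03 log units; within the scatter). Furan-3-yl alone therefore does not confer the low number of compound 1, 110 nM.

As far as these compounds go, it remains open whether methoxy is unique here, or whether ethoxy, an unsubstituted amine or chlorine would match it. From the compounds shown here alone, the effect of phenyl alongside methoxy also remains open.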